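Triazole-linked tetracyclic series: aryl substituent at cytotoxic ceiling

A few compounds are considered here, and "the series" means these few. Any claim that something is new, unique, unknown or untested is made for them only; others in the source may bear on it.

Measured compounds:
Compound 1 `C=C1C[C@]23C[C@@]1(O)CC[C@@H]2c1cccc(C)c1[C@@H]3Cn1cc(-c2ccc(C)cc2)nn1`: > 20000 nM
Compound 2 `C=C1C[C@]23C[C@@]1(O)CC[C@H]2c1ccc(OS(=O)(=O)c2ccc(C)cc2)c(C)c1[C@@H]3Cn1cc(-c2ccc(OC)cc2)nn1`: > 20000 nM
Compound 3 `COc1ccc(-c2cn(C[C@H]3c4c(ccc(O)c4C)[C@@H]4CC[C@@]5(C)C[C@]43CC5=O)nn2)cc1`: > 20000 nM

All three values are limits of the assay, not numbers. In a functional assay on MCF7 cells (Homo sapiens) for cytotoxicity, read by MTT assay, with a stated time of 4 days (on this read-out higher numbers stand for weaker inhibition and lower numbers for stronger inhibition), compound 1 sits at that limit, as do compound 2 and compound 3, so nothing separates them; the shared feature is the limit of > 20000 nM in this assay, at which 3 of the 3 values shown sit. Within the data shown here, no pair differing in one place has been measured, so no step size is available for comparison.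

Compound 4 `C=C1C[C@]23C[C@@]1(O)CC[C@@H]2c1cccc(C)c1[C@@H]3Cn1cc(-c2ccc(Br)cc2)nn1` is yet to be measured. It differs from compound 1 by bromo in place of methyl on an aromatic carbon.

Given that compound 1 gives only a limit in this assay, compound 4 is expected to remain near that ceiling, with no step beyond the scatter and no clear direction. The estimate for compound 4 is 30000 nM, spanning 8000 nM to 120000 nM. The step this estimate implies is a step that the limit leaves unreadable from compound 1 to compound 4, expected to be within the scatter.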

Compound 4, half-maximal inhibitory concentration: > 20000 nM
Compound 4: a limit, no number (the forecaster's own chance of this, stated with the estimate: 80%); the middle value lies beyond the limit too.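

Compound 1 and compound 4 both give only a limit, so no step can be read for 4-methylphenyl to 4-bromophenyl. In this assay the compounds shown leave open whether any aryl substituent on the shared core gives a number rather than a limit.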